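The compounds below may be only part of what the source reports. "The series", "measured", "known", "first", "only" and "open" are said of these compounds alone.

Working notes on the series. Compound 1 `COc1cc2ncnc(Nc3cccc(C(F)(F)F)c3)c2c(OC)c1OC`, compound 2 `COc1cc2ncnc(Nc3ccc([N+](=O)[O-])cc3)c2c(OC)c1OC` and compound 3 `COc1cc2ncnc(Nc3ccc(C(F)(F)F)cc3)c2c(OC)c1OC` share one core and differ only in the group carried on an aromatic carbon of a six-membered aromatic ring of carbon only, and in where on that ring it sits. In a functional assay on PC-3 cells (Homo sapiens) for inhibition, read by MTT assay, with a stated time of 72 h, tested at 1 uM (a lower number here means less inhibition of growth, a higher number more inhibition of growth at the concentration tested), compound 1 gives 14.9%. In this assay compound 2 gives 7.9%. In this assay compound 3 gives 7.4%. All three numbers lie within the usual scatter of one another, so no order among them is read from these data.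

Compound 1 and compound 3 are built from the same atoms joined differently; the difference between the two cores is not broken down here.

One measured step is available. From compound 3 to compound 2 the change is nitro in place of trifluoromethyl on an aromatic carbon, and in this assay it gives a number 0.5 percentage points higher from compound 3 to compound 2 (within the scatter).

Compound 4 `COc1cc2ncnc(Nc3cccc([N+](=O)[O-])c3)c2c(OC)c1OC` is not yet measured. It differs from compound 1 by nitro in place of trifluoromethyl on an aromatic carbon. The two changes are the same kind of change, not the same: in compound 2 the nitro stands para to a large group, in compound 4 it stands meta to a large group.

Resting on the one measured step, which was a number 0.5 percentage points higher from compound 3 to compound 2 (within the scatter), the step from compound 1 to compound 4 in this assay is expected to be small as well, a number 0.1 percentage points higher from compound 1 to compound 4 (within the scatter). Compound 4 is accordingly estimated at 15% in this assay, with an expected range from 5% to 26%. The measured number for compound 4 is awaited.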

Compound 4, percent growth inhibition at one concentration: 14.5%
For compound 4 the middle estimate is 0.5 percentage points above the measured one, within the range that was stated.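

In this assay, among these compounds, nitro in place of trifluoromethyl on an aromatic carbon gives a number 0.4 percentage points lower from compound 1 to compound 4 (within the scatter), so the second core also shows no step that can be told from the scatter. Set beside the step on the other core, this result shows no difference between the two cores: the same change on two cores in this assay, a number 0.5 percentage points higher (within the scatter) from compound 3 to compound 2 and a number 0.4 percentage points lower (within the scatter) from compound 1 to compound 4, 0.9 percentage points apart, within the scatter of two such steps. This supports only a limited statement, that in this series and at this single concentration the exchange of these two groups left the reading within the scatter on both cores; it does not show that the change carries over generally, that a real core dependence smaller than the scatter is absent, or that the same would hold in another assay or at another concentration.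

The compounds shown carry only trifluoromethyl or nitro on that ring, so they leave open how an amine, a carboxylic acid or a longer chain in the same place would read in this assay. They also leave open whether any change at that place can give a step beyond the scatter on either core.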